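Second chloro on the aryl piperazine of compound 2

The source may hold more compounds than are shown below. What is called first, only, known or untested is meant among the compounds shown, and "the series" means these compounds.

Of the compounds shown here, two have been measured so far. Compound 1 `O=S(=O)(c1cccc2ncccc12)N1CCC(CCN2CCN(c3ccccc3)CC2)CC1` gives 6710 nM in an assay on HEK293 cells for displacement of a labelled ligand from 5-hydroxytryptamine receptor 6 (Homo sapiens), read by scintillation counting, with a stated time of 1 h; a higher number here means a weaker inhibitor, a lower number a stronger inhibitor. Compound 2 `O=S(=O)(c1cncc2ccccc12)N1CCC(CCN2CCN(c3cccc(Cl)c3)CC2)CC1` gives 1190 nM in this assay, the lowest of the two numbers; compound 1 stands above it by a gap that lies beyond the usual scatter. Compound 3 `O=S(=O)(c1cncc2ccccc12)N1CCC(CCN2CCN(c3ccc(Cl)c(Cl)c3)CC2)CC1` has not yet been measured. It differs from compound 2 by one change: chloro in place of hydrogen on an aromatic carbon, with chloro in place of hydrogen on an aromatic carbon, so that the 3-chlorophenyl becomes a 3,4-dichlorophenyl. Within the data shown here, no measured pair in this set shows a step of that kind, so the expectation rests on compound 2 alone. The step of a 1.5-fold lower number from compound 2 to compound 3 (0.17 log units; within the scatter) is expected to be small, at most a modest move toward a lower number, and may fall within the scatter. Compound 3 is estimated at 800 nM in this assay, within a range from 300 nM to 2500 nM.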

Compound 3, inhibition constant: 1040 nM
Compound 3: the middle estimate sits 1.3-fold (0.11 log units) below what was measured, within the range that was stated.
By their numbers in this assay, from the lowest: compounds 3 and 2 (each within the scatter of the next); then compound 1.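

In this assay, among these compounds, the new chloro, placed ortho to a chloro group and para to a large group, gives a 1.1-fold lower number from compound 2 to compound 3 (0.06 log units; within the scatter), the first step in this set that isolates a single change on the aryl ring. Turning 3-chlorophenyl into 3,4-dichlorophenyl therefore produces no readable difference, and compound 2 and compound 3 cannot be told apart in this measurement. Nothing available offers an explanation for this result.

As far as these compounds go, it remains open whether another group at this position, such as methoxy, an amine or a carboxylic acid, would move the number beyond the scatter from compound 2. Among the compounds shown here, the effect of the first chloro also remains open, since compound 1 differs from compound 2 in more than one place and provides no single-change step for it.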